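The compounds below may be only part of what the source reports. "The series", "measured", "known", "first", "only" and "open" are said of these compounds alone.

Measured so far in a functional assay on CCRF-CEM cells (Homo sapiens) for antiproliferative activity; a lower number here means a stronger inhibitor of growth, a higher number a weaker inhibitor of growth:
- compound 1 `COCCCCCCCCCCCCCCC/C=C1/CC(CO)(COC(=O)C(C)(C)C)OC1=O` gives < 0.1 ug/mL as a limit of the assay, not a number
- compound 2 `COCCCCCCCCCCCCCCC/C=C1\CC(CO)(COC(=O)C(C)(C)C)OC1=O` gives 4.26 ug/mL as a number
- compound 3 `COC(=O)CCCCCCCCCCCCCC/C=C1\CC(CO)(COC(=O)C(C)(C)C)OC1=O` gives 0.691 ug/mL as a number

Compound 2 holds the higher of the two actual numbers, and the gap to its nearest neighbour is a 6.2-fold lower number from compound 2 to compound 3 (0.79 log units; beyond the scatter) in size.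

Compound 4 `CCCCCCCCC(O)CCCCCC/C=C1\CC(CO)(COC(=O)C(C)(C)C)OC1=O` has not yet been measured. It carries 1-hydroxynonyl in place of 9-methoxynonyl on a saturated chain carbon, six bonds along the chain from a double-bonded chain carbon.

The large step of an at least 42-fold higher number from compound 1 to compound 2 (1.62 log units; beyond the scatter) concerns the double bond, which compound 4 keeps as drawn in compound 2, so it offers little guidance here. The closer guide is the chain change a 6.2-fold lower number from compound 2 to compound 3 (0.79 log units; beyond the scatter) as a modest step, though it involves a different group. A modest move toward a lower number in this assay is therefore expected, but with wide uncertainty. The expected step is a 2.4-fold lower number from compound 2 to compound 4 (0.37 log units; beyond the scatter) in size. For compound 4 the estimated value is 1.8 ug/mL with an expected range from 0.4 ug/mL to 8 ug/mL in this test.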

Compound 4, concentration for 50% growth inhibition: 5.72 ug/mL
For compound 4 the middle estimate is 3.2-fold (0.50 log units) below the measured one, within the range that was stated.
By their numbers in this assay, from the lowest: compound 3; then compounds 2 and 4 (each within the scatter of the next). At a limit, below all of these: compound 1.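

Replacing 9-methoxynonyl with 1-hydroxynonyl in this assay gives a 1.3-fold higher number from compound 2 to compound 4 (0.13 log units; within the scatter) so this assay cannot tell the two compounds apart. The new chain carries a hydrogen-bond donor and the old one has none, so this result shows that the chain can take that swap with no change beyond the scatter. The earlier chain change, with methoxycarbonyl in place of methoxymethyl, gave a 6.2-fold lower number from compound 2 to compound 3 (0.79 log units; beyond the scatter) and is thus the only one of these two chain changes to move the number beyond the scatter.

The compounds shown leave open how a chain ending in an amine or a carboxylic acid would behave, and whether 1-hydroxynonyl would read the same with the double bond drawn as in compound 1. Nothing measured here bears on why this swap changes so little.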